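Swapping the Bicyclic Amide Head of Compound 2

A few compounds are considered here, and "the series" means these few. Any claim that something is new, unique, unknown or untested is made for them only; others in the source may bear on it.

Of the compounds shown here, three have so far been measured in an assay for inhibition of Nicotinamide phosphoribosyltransferase (Homo sapiens), read by mass spectrometry, with stated times of 15 min and 30 min; a higher number here means a weaker inhibitor, a lower number a stronger inhibitor. Compound 1 `O=C(NCc1ccc(S(=O)(=O)c2ccccc2)cc1)c1ccc2ccncc2c1` gives 610 nM. Compound 2 `O=C(NCc1ccc(S(=O)(=O)c2ccccc2)cc1)c1nc2cnccc2[nH]1` gives 7100 nM, the highest number of the three and therefore the weakest inhibitor of this set: compound 1 lies well beyond the scatter below it, and compound 3 lies further still. Compound 3 `O=C(NCc1ccc(S(=O)(=O)N2CCCCC2)cc1)c1cc2ccncc2o1` gives 40 nM; it differs from compound 2 in more than one place, so only its number can be set beside the others.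

Compound 4 `O=C(NCc1ccc(S(=O)(=O)c2ccccc2)cc1)c1ccc2nccn2c1` has not yet been measured. It differs from compound 2 in one place: a group of 9 heavy atoms (7 carbon, 2 nitrogen; one five-membered aromatic ring with 2 hetero atoms, one six-membered aromatic ring with 1 hetero atom) in place of a group of 9 heavy atoms (6 carbon, 3 nitrogen; one five-membered aromatic ring with 2 hetero atoms, one six-membered aromatic ring with 1 hetero atom), on a carbonyl carbon. For the measured compounds named here, no measured pair shows this change on its own, so the expected step must rest on the other amide heads seen here. Because compound 1, carrying the same sulfone side chain with a different bicyclic amide head, gives 610 nM, the step from compound 2 to compound 4 is expected to be a 12-fold lower number from compound 2 to compound 4 (1.07 log units; beyond the scatter), towards a stronger inhibitor, though with considerable uncertainty. Compound 4 is expected to give about 600 nM, with a plausible range from 150 nM to 2500 nM.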

Compound 4, half-maximal inhibitory concentration: 18 nM
The estimate for compound 4 lay 33-fold (1.52 log units) above the measured number, and the stated range ends above it.
By their numbers in this assay, from the lowest: compound 4; then compound 3; then compound 1; then compound 2.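

With the sulfone side chain unchanged, the amide head alone accounts for a 390-fold lower number from compound 2 to compound 4 (2.60 log units; beyond the scatter) in this assay, so this place on the carbonyl carbon responds very strongly to the choice of bicyclic group. The two groups are closely matched in what can be counted: both have 9 heavy atoms and the same ring types, while the entering group has one more carbon, one fewer nitrogen and 0 hydrogen-bond donors where the leaving group has 1. No measurement here explains why the step is so large.

This single pair cannot separate the lost donor from the changed nitrogen count, and a head like that of compound 2 with a methyl group replacing its donor hydrogen would bear on that question. Going by these compounds, it also remains open whether the head of compound 4 would keep its effect on the side chain of compound 3.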